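Swapping an acetamido for a hydroxy on a thiazole amide

The source may report more compounds than this note shows. Statements on the series, on what has been measured and on what is new or still open speak of the compounds shown alone.

Compound 1 `CC(=O)NCc1csc(NC(=O)c2cc(C(C)(C)C)nn2Cc2ccccc2)n1` and compound 2 `COc1ccc(C(=O)Nc2nc(CN)cs2)cc1` were both measured in a physicochemical assay for lipophilicity, read by HPLC, at pH 3.0; a lower number here means a more polar compound, a higher number a more lipophilic compound. In this assay compound 1 gives 3.3, the higher of the two numbers. In this assay compound 2 gives 0.9, a value that lies well beyond the usual scatter below that of compound 1. No single-change comparison between these two exists, so their numbers can only be set side by side.

The next compound, compound 3 `CC(C)(C)c1cc(C(=O)Nc2nc(CO)cs2)n(Cc2ccccc2)n1`, differs from compound 1 in one place: hydroxy in place of acetamido on a saturated chain carbon bound to an aromatic carbon. Cut one bond further out, the same change reads acetamidomethyl to hydroxymethyl.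

Within the data shown here, with no measured step of this kind available, a modest shift is expected, in the lower direction, amounting to a number 0.40 log units lower from compound 1 to compound 3 (beyond the scatter). Compound 3 is therefore expected to give about 2.9 in this assay, somewhere between 2.3 and 3.5.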

Compound 3, distribution coefficient: 3.5
The estimate for compound 3 lay 0.60 log units below the measured number, and the stated range covers the measured number.
By their numbers in this assay, from the lowest: compound 2; then compounds 1 and 3 (each within the scatter of the next).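

Among these compounds, this is the first measured step at this position: with hydroxy in place of acetamido on a saturated chain carbon bound to an aromatic carbon, the reading in this assay is a number 0.20 log units higher from compound 1 to compound 3 (within the scatter). The group that leaves has 4 heavy atoms and the group that enters has 1, yet this measurement cannot tell the two compounds apart, so on this core the difference in group size comes with no step beyond the scatter. Nothing available explains this result.

Going by these compounds, whether a carboxylic acid, a methoxy group or a longer chain such as hydroxyethyl would also stay within the scatter at this place remains open. Also open, on these data alone, is whether the same swap would give a similar step on a different core, such as that of compound 2.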